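The compounds below may be only part of what the source reports. "The series", "measured", "known", "first", "only" and "open" are said of these compounds alone.

Compound 3 `COc1cc(Cl)cc(-c2nn(-c3cccc(NC(=O)Nc4ccc(Cl)c(Cl)c4)c3)cc2-c2ccncc2)c1` in a functional assay on UO-31 cells (Homo sapiens) for inhibition, read by sulforhodamine B assay, with a stated time of 48 h (a higher number here means a weaker inhibitor, a lower number a stronger inhibitor), gives 1890 nM. Among the three measured compounds this is the second highest number; compound 1 `O=C(Nc1cccc(-n2cc(-c3ccncc3)c(-c3cc(O)cc(Cl)c3)n2)c1)Nc1ccc(Cl)c(Cl)c1` gives 1910 nM, and the step of a 1.0-fold lower number from compound 1 to compound 3 (0.00 log units; within the scatter) is within the scatter. Within the data shown here, compound 2 `COc1cc(Cl)cc(-c2nn(-c3cccc(NC(=O)Nc4cc(C(F)(F)F)cc(C(F)(F)F)c4)c3)cc2-c2ccncc2)c1` gives 260 nM, a lower number than compound 3 by more than the scatter; no single-point step between these two is recorded, so only the two values can be compared. Compound 4 `COc1cc(Cl)cc(-c2nn(-c3cccc(NC(=O)c4cccc(C(F)(F)F)c4)c3)cc2-c2ccncc2)c1` differs from compound 3 by 3-(trifluoromethyl)phenyl in place of (3,4-dichlorophenyl)amino on a carbonyl carbon. Among the measured compounds shown here, none of the measured steps changes this part of the molecule, so the expectation rests on a loose analogy only. Compound 4 is expected to give a somewhat higher number, a step of a 2.1-fold higher number from compound 3 to compound 4 (0.33 log units; beyond the scatter), estimated at 4000 nM with a range from 1000 nM to 15000 nM.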

Compound 4, half-maximal inhibitory concentration: 2710 nM
Compound 4: the middle estimate sits 1.5-fold (0.17 log units) above what was measured, within the range that was stated.
By their numbers in this assay, from the lowest: compound 2; then compounds 3, 1 and 4 (each within the scatter of the next).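

The earlier step altered only a methyl on an oxygen, whereas this one changes the group on the carbonyl carbon, where 3-(trifluoromethyl)phenyl replaces (3,4-dichlorophenyl)amino. In this assay, this gives a 1.4-fold higher number from compound 3 to compound 4 (0.16 log units; within the scatter), so the swap, which also loses the hydrogen-bond donor of the leaving group, leaves the number within the scatter. No available measurement explains this result. Still open is whether this position needs an aromatic ring at all, since a morpholine or a short alkyl chain on the same carbonyl carbon lies outside the compounds shown.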